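The compounds below may be only part of what the source reports. "The series", "measured", "known", "first", "only" and "open" are said of these compounds alone.

Measured compounds:
compound 1 `COc1cc(-c2cc(/C=C/C(=O)c3ccc(C)c(C)c3)nc3cc(-c4ccccc4)nn23)cc(OC)c1OC` gives 13500 nM in a functional assay on MDA-MB-231 cells (Homo sapiens) for antiproliferative activity, read by MTT assay, with a stated time of 24 h; on this read-out lower numbers stand for stronger inhibition and higher numbers for weaker inhibition;
compound 2 `COc1ccc(C(=O)/C=C/c2cc(-c3ccc(OC)c(OC)c3)n3nc(-c4ccccc4)cc3n2)cc1` gives 13900 nM in this assay.

Compound 1 shows the lower of the two numbers, but its gap to compound 2 lies within the usual scatter of this assay, so the two cannot be told apart. Compound 3 `COc1cc(-c2cc(/C=C/C(=O)c3ccccc3)nc3cc(-c4ccccc4)nn23)cc(OC)c1OC` is not yet measured. It differs from compound 1 in one place: phenyl in place of 3,4-dimethylphenyl on a carbonyl carbon. Nothing measured here shows what this change does, so no step beyond the scatter is expected. The step from compound 1 to compound 3 is expected to be a 1.1-fold higher number from compound 1 to compound 3 (0.05 log units; within the scatter). Compound 3 is estimated at 15000 nM, between 7000 nM and 35000 nM.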

Compound 3, half-maximal inhibitory concentration: 15800 nM
The estimate for compound 3 lay 1.1-fold (0.02 log units) below the measured number; measured number inside the range.
By their numbers in this assay, from the lowest: compounds 1, 2 and 3 (each within the scatter of the next).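

Phenyl in place of 3,4-dimethylphenyl on the carbonyl carbon gives a 1.2-fold higher number from compound 1 to compound 3 (0.07 log units; within the scatter) in this assay. The two methyl groups can therefore be absent from this ring without a difference that this read-out can separate from repeat-measurement scatter. Nothing available explains this result. The compounds shown leave open whether a group of another kind on this ring, such as an amine or a carboxylic acid, would move the number beyond the scatter. On these data alone, whether a ring containing nitrogen in place of phenyl would do so also remains unknown.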